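The source may hold more compounds than are shown below. What is called first, only, known or untested is meant among the compounds shown, and "the series" means these compounds.

In a physicochemical assay for lipophilicity, measured as octanol-water partition, at pH 7.4 (on this read-out higher numbers stand for higher lipophilicity and lower numbers for lower lipophilicity), three compounds built on a shared core have been measured: compound 1 `Cc1ccc2[nH]c(C(=O)N[C@H]3CN(S(=O)(=O)c4cn(C)nc4C)C[C@@H]3C(=O)NCCN(C)C)cc2c1` gives 1.4, compound 2 `Cc1ccc2[nH]c(C(=O)N[C@H]3CCN(S(=O)(=O)c4cccnc4)C[C@@H]3C(=O)NCCN(C)C)cc2c1` gives 1.3, and compound 3 `Cc1ccc2[nH]c(C(=O)N[C@H]3CCN(S(=O)(=O)C4CC4)C[C@@H]3C(=O)NCCN(C)C)cc2c1` gives 1. Compound 3 therefore lies within the usual scatter of compound 2, while the gap between its value and that of compound 1 goes beyond that scatter.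

Compound 4 `Cc1ccc2[nH]c(C(=O)N[C@H]3CCN(S(=O)(=O)N(C)C)C[C@@H]3C(=O)NCCN(C)C)cc2c1` has not yet been measured. It differs from compound 3 in one place: dimethylamino in place of cyclopropyl on a sulfonyl sulfur. Among the measured compounds shown here, only one measured step changes a group at this same place: a number 0.30 log units lower from compound 2 to compound 3 (within the scatter), which stays within the scatter. That step involves a different pair of groups, so it offers only a rough guide to size and none to direction. A small upward move, no larger than the scatter, is expected in this assay, and the estimated step is a number 0.20 log units higher from compound 3 to compound 4 (within the scatter). For compound 4, the estimated value is 1.2, with an expected range from 0.8 to 1.6.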

Compound 4, distribution coefficient: 1.2
Compound 4: the middle estimate sits on the measured number at the digits printed; the measured number falls inside the stated range.
By their numbers in this assay, from the lowest: compounds 3, 4, 2 and 1 (each within the scatter of the next, the first and the last beyond it).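

In this assay, dimethylamino in place of cyclopropyl on a sulfonyl sulfur gives a number 0.20 log units higher from compound 3 to compound 4 (within the scatter), while dimethylamino in place of pyridin-3-yl gives a number 0.10 log units lower from compound 2 to compound 4 (within the scatter). Compounds 2, 3 and 4 therefore show that this place can hold an aromatic ring, a three-membered carbon ring or a group with no ring and a nitrogen attached to the sulfur, with no listed step among them going beyond the scatter. No measurement is available that would explain these small steps.

On these data alone, it remains open whether a longer carbon chain, a carboxylic acid or a primary amine at this place would produce a step beyond the scatter. It is also unknown whether dimethylamino would give a similar step on the core of compound 1.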